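Dienone series: nitrophenyl in place of pyridyl on the arm

This account rests on a few compounds, and the source may have more. Where it says the series, first, only, none or still open, it means among the compounds named here.

Among the compounds with values here, compound 1 `O=C(/C=C/c1ccc(Oc2cc(=O)oc3ccccc23)cc1)/C=C/c1ccccn1` and compound 2 `COc1cc(OC)c2c(=O)c(OCCCOc3ccccc3/C=C/C(=O)/C=C/c3ccccn3)c(-c3cc(OC)c(OC)c(OC)c3)oc2c1` are the two members measured so far. In a functional assay on SMMC-7721 cells (Homo sapiens) for antiproliferative activity, read by MTT assay, with a stated time of 48 h (a lower number here means a stronger inhibitor, a higher number a weaker inhibitor), compound 1 gives 35400 nM. In this assay compound 2 gives 3180 nM, the lower of the two numbers, and the gap to compound 1 lies beyond the scatter of repeated measurements. Compound 3 `COc1cc(OC)c2c(=O)c(OCCCOc3ccccc3/C=C/C(=O)/C=C/c3cccc([N+](=O)[O-])c3)c(-c3cc(OC)c(OC)c(OC)c3)oc2c1` is the next member and has not yet been measured. It differs from compound 2 in one place: 3-nitrophenyl in place of pyridin-2-yl on a double-bonded chain carbon bound to a double-bonded chain carbon. Within the data shown here, no pair of measured compounds shows this same change, so no reference step exists for it. Among the measured compounds shown here, the only measured comparison, compound 1 against compound 2, concerns a different part of the molecule and says nothing about the arm that changes here. Without such a reference, the expectation for compound 3 in this assay is a step of modest size in either direction, most likely not beyond the scatter. The expected step is a 1.1-fold higher number from compound 2 to compound 3 (0.04 log units; within the scatter). The estimate for compound 3 in this assay is 3500 nM, with a range from 1200 nM to 11000 nM.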

Compound 3, half-maximal inhibitory concentration: 9200 nM
For compound 3 the middle estimate is 2.6-fold (0.42 log units) below the measured one, within the range that was stated.
By their numbers in this assay, from the lowest: compound 2; then compound 3; then compound 1.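

In this assay, 3-nitrophenyl in place of pyridin-2-yl on a double-bonded chain carbon bound to a double-bonded chain carbon gives a 2.9-fold higher number from compound 2 to compound 3 (0.46 log units; beyond the scatter), so the group at this end of the arm does affect the read-out. Within the data shown here, compound 1 and compound 2 both carry pyridin-2-yl here and differ elsewhere, so neither could show this; the pair of compound 2 and compound 3 is the first single-place reading of this position, and it favours pyridin-2-yl over 3-nitrophenyl. Nothing shown gives a reason for the step, and a single pair supports no wider trend across the series.

The change swaps a ring containing nitrogen for an all-carbon ring and also adds a nitro group, going from 6 to 9 heavy atoms, so the compounds shown cannot separate these differences; an unsubstituted phenyl at this place would divide them, and an amine or a carboxylic acid on the phenyl ring would test other substituents. Also open, on these data alone, is whether the step would hold on the core of compound 1, or with a longer or shorter chain joining the arm to the core of compound 2.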